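Swapping 3,4-dichlorophenyl for 3,4-difluorophenyl on a shared core

The source may hold more compounds than are shown below. What is called first, only, known or untested is meant among the compounds shown, and "the series" means these compounds.

Measured so far in an assay on HEK293 cells for activation of Kir3.1/Kir3.2 (Homo sapiens), read by thallium flux; a higher number here means that more compound is needed for the effect, a lower number that less compound is needed:
compound 1, `Cc1cc(NC(=S)Cn2nnc(-c3ccccc3)n2)n(C2CCCCC2)n1`, gives 623 nM;
compound 2, `O=C(Cn1nnc(-c2ccccc2)n1)Nc1ccccn1`, gives "not active" (no number reported);
compound 3, `Cc1cc(NC(=O)Cn2nnc(-c3ccc(Cl)c(Cl)c3)n2)n(C2CCCCC2)n1`, gives 1220 nM.

Compound 3 is one of two compounds with a number in this assay. Compound 1 comes nearest to it, and its number sits within the usual scatter of that of compound 3, so the two cannot be told apart. Compound 2 gives no single number at all.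

The unmeasured compound 4, `Cc1cc(NC(=O)Cn2nnc(-c3ccc(F)c(F)c3)n2)n(C2CCCCC2)n1`, differs from compound 3 in one place: 3,4-difluorophenyl in place of 3,4-dichlorophenyl on an aromatic carbon. Within the data shown here, no measured pair shows this exchange, so nothing in the set says which way it turns. With the halogen pair on the same ring changed and all else held, the expectation is a step of at most modest size, quite possibly none beyond the scatter, and if anything toward a higher number. The step of a 1.2-fold higher number from compound 3 to compound 4 (0.09 log units; within the scatter) is thus expected to stay small. Compound 4 is estimated at 1500 nM, between 600 nM and 4000 nM.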

Compound 4, half-maximal effective concentration: 116 nM
Estimate against measurement, compound 4: 13-fold (1.11 log units) above; the whole stated range lies above it.
By their numbers in this assay, from the lowest: compound 4; then compounds 1 and 3 (each within the scatter of the next).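

In this assay, among these compounds, replacing 3,4-dichlorophenyl with 3,4-difluorophenyl gives an 11-fold lower number from compound 3 to compound 4 (1.02 log units; beyond the scatter), the first step that can be read at this position. The two halogen pairs are therefore not interchangeable here: although the exchange leaves the heavy-atom count unchanged and adds no hydrogen-bond donors or acceptors, less of the difluorophenyl compound is needed for the effect. No measurement at hand accounts for the size of this step.

Going by these compounds, it remains open whether a single fluorine, a methoxy group or a nitrile on this phenyl ring would move the number in the same direction. It is also unknown whether the same halogen exchange would give a step of similar size on the core of compound 1 .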